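Two Drawings of One Stereocentre, and a Third to Come

This account rests on a few compounds, and the source may have more. Where it says the series, first, only, none or still open, it means among the compounds named here.

Measured in a functional assay on P388 cells (Mus musculus) for cytotoxicity; on this read-out lower numbers stand for stronger inhibition and higher numbers for weaker inhibition:
Compound 1 `CCC1CCCN1CN1C(=O)c2cccc3c2c(cc2c4ccccc4sc32)C1=O`: 470 nM
Compound 2 `CC[C@H]1CCCN1CN1C(=O)c2cccc3c2c(cc2c4ccccc4sc32)C1=O`: 4900 nM

Compound 2 stands highest of the two, making it the weaker. Going by the values given here, the one measured step that bears on what follows is a 10-fold higher number from compound 1 to compound 2 (1.02 log units; beyond the scatter), a large step beyond the scatter, and the only difference behind it is the fact that one of compounds 1 and 2 is drawn with a defined configuration and the other without, at the place where they differ. Compound 3 `CC[C@@H]1CCCN1CN1C(=O)c2cccc3c2c(cc2c4ccccc4sc32)C1=O` changes that same centre: the two compounds have the same atoms and bonds and differ only in configuration as drawn: 1 of 1 stereo elements differ; a stereocentre at a saturated ring carbon is drawn S in compound 2 and R in compound 3. Nothing leaves or enters. If compound 1 is a mixture of both configurations, compound 2, the S form, cannot account for the value of compound 1 470 nM given a 10-fold higher number from compound 1 to compound 2 (1.02 log units; beyond the scatter). The R form should then carry most of the effect. The expected change is a 19-fold lower number from compound 2 to compound 3 (1.28 log units; beyond the scatter), a large step to a lower number. For compound 3 the estimated value is 260 nM, within an expected range of 100 nM to 700 nM.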

Compound 3, half-maximal inhibitory concentration: 2280 nM
Compound 3: middle estimate off by 8.8-fold (0.94 log units), on the low side; measured number above the stated range.
By their numbers in this assay, from the lowest: compound 1; then compound 3; then compound 2.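

Reversing the drawn configuration at the saturated ring carbon in this assay gives only a 2.1-fold lower number from compound 2 to compound 3 (0.33 log units; beyond the scatter) and so the R form does not carry the effect seen in compound 1. The undefined drawing also keeps its lead over this form, with a 4.9-fold higher number from compound 1 to compound 3 (0.69 log units; beyond the scatter) and both defined drawings therefore read weaker than compound 1. Neither single configuration accounts for the value of compound 1, and the comparison rests on a difference in drawing alone: the fact that one of compounds 1 and 3 is drawn with a defined configuration and the other without, at the place where they differ

Why compound 1 gives the lowest number stays open. So does whether configuration at this carbon would matter as much with a longer chain or a carboxylic acid in place of the present chain.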